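The compounds below may be only part of what the source reports. "The series", "measured", "known", "first", "only" and "open" are said of these compounds alone.

In a functional assay on HL-60 cells (Homo sapiens) for antiproliferative activity, with a stated time of 72 h (on this read-out lower numbers stand for stronger inhibition and higher numbers for weaker inhibition), compound 1 `OC[C@H]1O[C@@H](n2cnc3c(NCc4ccccc4F)ncnc32)[C@H](O)[C@@H]1O` gives 3200 nM, the lowest of the three numbers in hand. Compound 2 `OC[C@H]1O[C@@H](n2cnc3c(NCc4cccc(Br)c4)ncnc32)[C@H](O)[C@@H]1O` gives 8000 nM and compound 3 `OC[C@H]1O[C@@H](n2cnc3c(NCc4ccc(F)c(F)c4F)ncnc32)[C@H](O)[C@@H]1O` gives 13000 nM. The two steps away from compound 1 both raise the number: a 2.5-fold higher number from compound 1 to compound 2 (0.40 log units; beyond the scatter) and a 4.1-fold higher number from compound 1 to compound 3 (0.61 log units; beyond the scatter). Between the other two, a 1.6-fold higher number from compound 2 to compound 3 (0.21 log units; within the scatter), so those two cannot be told apart on these data.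

Compound 4 `OC[C@H]1O[C@@H](n2cnc3c(NCc4ccc(F)cc4Cl)ncnc32)[C@H](O)[C@@H]1O` differs from compound 1 by 2-chloro-4-fluorophenyl in place of 2-fluorophenyl on a saturated chain carbon bound to a nitrogen on an aromatic ring. Both measured steps that start from compound 1 exchange the 2-fluorophenyl for another halogen-bearing phenyl, and both end at a higher number in the modest range; nothing among the three shows such an exchange lowering the number. The replacement in compound 4 is of the same kind, so a modest rise in this assay is expected rather than a large one, and a result within the scatter of compound 1 cannot be ruled out. The expected step is a 1.9-fold higher number from compound 1 to compound 4 (0.27 log units; within the scatter). Compound 4 is therefore estimated at 6000 nM, with a range from 2500 nM to 15000 nM.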

Compound 4, half-maximal inhibitory concentration: 9000 nM
Estimate against measurement, compound 4: 1.5-fold (0.18 log units) below; measured number inside the range.
By their numbers in this assay, from the lowest: compound 1; then compounds 2, 4 and 3 (each within the scatter of the next).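

In this assay, a third exchange of the 2-fluorophenyl on a saturated chain carbon bound to a nitrogen on an aromatic ring ends beyond the scatter (a 2.8-fold higher number from compound 1 to compound 4 (0.45 log units; beyond the scatter)), so all three replacements shown at this place go the same way and compound 1 remains apart from the others. Here the 2-fluorophenyl is not swapped for a different halogen pattern alone: the entering 2-chloro-4-fluorophenyl keeps one fluorine and adds one chlorine, and that still does not bring the number back towards compound 1. The three replacements cannot be separated from each other (a 1.4-fold lower number from compound 3 to compound 4 (0.16 log units; within the scatter); a 1.1-fold higher number from compound 2 to compound 4 (0.05 log units; within the scatter)), so on these data the 3-bromophenyl, 2,3,4-trifluorophenyl and 2-chloro-4-fluorophenyl groups form a single level, and no measurement offered here accounts for the gap to compound 1.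

Open, from the compounds shown here alone, is how compound 1 at 3200 nM compares with an unsubstituted benzyl, a methoxyphenyl, an aminomethylphenyl or a longer chain such as 2-phenylethyl at the same place. All four compounds carry a halogen-bearing phenyl on the shared core, so these data give no reading on non-halogen groups at this place or on changes elsewhere in the core.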